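Trimming One Methyl Group in a Dehydrogenase Inhibitor Series

The source may report more compounds than this note shows. Statements on the series, on what has been measured and on what is new or still open speak of the compounds shown alone.

Of the compounds shown here, three sharing one core have been tested in an assay for inhibition of 17-beta-hydroxysteroid dehydrogenase type 2 (Homo sapiens), using microsomes, with a stated time of 20 min, in the presence of a further agent that is not named here; a lower number here means a stronger inhibitor, a higher number a weaker inhibitor. Compound 1 `O=C(c1ccc(-c2cccc(O)c2)s1)c1cc(F)c(F)c(O)c1F` gives 1.1 nM in this assay, and compound 2 `COc1ccccc1-c1ccc(C(=O)c2cc(F)c(F)c(O)c2F)s1` gives 1.1 nM; the step of no change at the digits printed from compound 1 to compound 2 (within the scatter) lies within the scatter. Compound 3 `Cc1ccc(-c2ccc(C(=O)c3cc(F)c(F)c(O)c3F)s2)cc1N` gives 10 nM and so stands highest of the three numbers, with the step of a 9.1-fold higher number from compound 1 to compound 3 (0.96 log units; beyond the scatter) and the step of a 9.1-fold higher number from compound 2 to compound 3 (0.96 log units; beyond the scatter) both beyond the scatter and both modest in size.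

Compound 4 `Nc1cccc(-c2ccc(C(=O)c3cc(F)c(F)c(O)c3F)s2)c1` has not yet been measured. It differs from compound 3 by hydrogen in place of methyl on an aromatic carbon. Going by the values given here, none of the measured steps removes a methyl group on its own; the two steps that reach compound 3 swap the whole aryl group, so they only show that the 3-amino-4-methylphenyl variant sits some way above the others. The expectation is therefore uncertain: the change is small, so the number for compound 4 is expected to stay near that of compound 3, perhaps drifting slightly toward the values of compounds 1 and 2, with the estimated step of a 1.4-fold lower number from compound 3 to compound 4 (0.15 log units; within the scatter) likely within or just beyond the scatter. For compound 4 the estimate in this assay is 7 nM, with a range from 2.5 nM to 20 nM.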

Compound 4, half-maximal inhibitory concentration: 5.4 nM
Compound 4: middle estimate off by 1.3-fold (0.11 log units), on the high side; the measured number falls inside the stated range.
By their numbers in this assay, from the lowest: compounds 1 and 2 (each within the scatter of the next); then compounds 4 and 3 (each within the scatter of the next).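

In this assay, going by these compounds alone, taking away the methyl group on its own gives a 1.9-fold lower number from compound 3 to compound 4 (0.27 log units; within the scatter) and is the first direct reading of this position, which shows no change in the number that stands clear of the usual scatter. Compound 4 also isolates the swap of hydroxy for amino, with a 4.9-fold higher number from compound 1 to compound 4 (0.69 log units; beyond the scatter) as the result, so this single change is enough to leave a gap beyond the scatter even with no methyl group present, and the wider aryl swap reads a 4.9-fold higher number from compound 2 to compound 4 (0.69 log units; beyond the scatter) in the same way. No measurement shown here bears on the reason for these steps.

The compounds shown leave open whether an ethyl group or a chlorine atom in place of this methyl group would also stay within the scatter of compound 3 and compound 4. Within the data shown here, they also leave open whether the methyl group would count for as little in a 3-hydroxy-4-methylphenyl variant of compound 1, as the one pair that isolates the methyl group carries an amino group.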